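The source may hold more compounds than are shown below. What is called first, only, known or untested is meant among the compounds shown, and "the series" means these compounds.

Among the measured compounds shown here, compound 1 `O=C1NC(=O)/C(=C/c2ccc(OCN3C(=O)c4ccccc4C3=O)c([N+](=O)[O-])c2)S1` is one of two compounds measured in an assay on isolated protein for inhibition of Alpha glucosidase (Homo sapiens), read by spectrophotometry, with stated times of 15 min and 30 min; on this read-out higher numbers stand for weaker inhibition and lower numbers for stronger inhibition; in this assay compound 1 gives 22500 nM, the higher of the two numbers. Its neighbour compound 2 `O=C1NC(=O)/C(=C/c2ccc(OCN3C(=O)c4ccccc4C3=O)c(Cl)c2)S1` gives 21000 nM, and the step of a 1.1-fold lower number from compound 1 to compound 2 (0.03 log units; within the scatter) shows how little that swap matters. Compound 3 `O=C1NC(=S)S/C1=C\c1ccc(OCN2C(=O)c3ccccc3C2=O)c([N+](=O)[O-])c1` differs from compound 1 by a group of 8 heavy atoms (4 carbon, 1 nitrogen, 1 oxygen, 2 sulfur; one five-membered non-aromatic ring with 2 hetero atoms) in place of a group of 8 heavy atoms (4 carbon, 1 nitrogen, 2 oxygen, 1 sulfur; one five-membered non-aromatic ring with 2 hetero atoms), on an aromatic carbon. For the measured compounds named here, no measured step covers this change, so the expectation rests on compound 1 alone. The expected step of a 1.4-fold lower number from compound 1 to compound 3 (0.15 log units; within the scatter) is estimated as small, and compound 3 is expected near 16000 nM, between 5000 nM and 50000 nM.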

Compound 3, half-maximal inhibitory concentration: 6590 nM
Compound 3: the middle estimate sits 2.4-fold (0.39 log units) above what was measured; the measured number falls inside the stated range.
By their numbers in this assay, from the lowest: compound 3; then compounds 2 and 1 (each within the scatter of the next).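

In this assay, this five-membered ring is the first place shown where a change moves the number beyond the scatter: the group with 1 oxygen and 2 sulfur, replacing the one with 2 oxygen and 1 sulfur, gives a 3.4-fold lower number from compound 1 to compound 3 (0.53 log units; beyond the scatter). Both groups have the same counts of heavy atoms, hydrogen-bond donors and acceptors, so those counts alone do not set the number. No measurement here accounts for the shift. Going by these compounds, it remains open whether the step would recur with chloro in place of nitro. Also open, on these data alone, is how a carboxylic acid or an amine on this ring would compare.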